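Furan-3-yl for pyridin-4-yl: working notes

The source may report more compounds than this note shows. Statements on the series, on what has been measured and on what is new or still open speak of the compounds shown alone.

In a functional assay on A-375 cells (Homo sapiens) for antiproliferative activity (on this read-out lower numbers stand for stronger inhibition and higher numbers for weaker inhibition), compound 1 (`O=C(Nc1ccc(-c2cscn2)cc1)C1CCN(Cc2ccc(F)c(F)c2)CC1`) gives > 20000 nM as a limit and not as a number. Compound 2 (`O=C(Nc1ccc(-c2cscn2)cc1)C1CCCN(Cc2ccc3cn[nH]c3c2)C1`) likewise gives > 20000 nM as a limit only. Going by the values given here, compound 3 (`O=C(Nc1ccc(-c2ccncc2)cc1)C1CCCN(Cc2ccc(F)c(F)c2)C1`) gives 600 nM as the only true number in the set. Compound 1 and compound 2 each differ from compound 3 in more than one place, so no single change can be read from them.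

Compound 4 (`O=C(Nc1ccc(-c2ccoc2)cc1)C1CCCN(Cc2ccc(F)c(F)c2)C1`) carries furan-3-yl in place of pyridin-4-yl on an aromatic carbon, para to a large group (furan-3-yl in place of pyridin-4-yl on an aromatic carbon) and is otherwise the same as compound 3. Among the compounds with values here, no measured step covers this exchange. A loss of potency beyond the scatter is expected, and the estimated step (a 4.2-fold higher number from compound 3 to compound 4 (0.62 log units; beyond the scatter)) is moderate in size, with a real chance that only a limit is reported. The estimate for compound 4 is 2500 nM within an expected range of 500 nM to 15000 nM in this assay on present evidence.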

Compound 4, half-maximal inhibitory concentration: 1290 nM
Compound 4: the middle estimate sits 1.9-fold (0.29 log units) above what was measured; low and high end bracket the measured number.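

In this assay, going by these compounds alone, the first single change that can be read is furan-3-yl in place of pyridin-4-yl on an aromatic carbon, para to a large group, and it gives a 2.2-fold higher number from compound 3 to compound 4 (0.33 log units; beyond the scatter). The step is modest but beyond the scatter, so this position responds to the exchange without the number being lost to a limit. In this one pair, a five-membered aromatic ring with oxygen as its hetero atom still gives a true number, so a measurable value at this position does not depend on pyridin-4-yl alone.

From the compounds shown here alone, how a plain phenyl or a pyridin-3-yl group would compare at this position remains open. Steps involving compound 1 and compound 2 cannot be read, as the values of both are limits and not numbers: the limit of > 20000 nM in this assay, at which 2 of the 4 values shown sit.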